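Swapping the thiophene for a bromoindole in compound 4

The source may report more compounds than this note shows. Statements on the series, on what has been measured and on what is new or still open speak of the compounds shown alone.

Of the compounds shown here, three in this set share one core and have been tested in a functional assay on DU-145 cells (Homo sapiens) for inhibition, read by trypan blue exclusion, with a stated time of 96 h; a higher number here means a weaker inhibitor of growth, a lower number a stronger inhibitor of growth. Compound 1 `Cc1ccsc1/C=C(/SCc1ccc(F)cc1)C(=O)c1ccc(Br)cc1` gives 50000 nM. Compound 2 `O=C(/C(=C\c1ccc(Cl)cc1)SCc1ccc(F)cc1)c1ccc(Cl)cc1` gives 10000 nM. Compound 3 `Cc1ccsc1/C=C(/SCc1ccc(F)cc1)C(=O)c1ccc(Cl)cc1` gives 50000 nM. Compound 3 thus stands level with compound 1, the two together at the highest numbers here, and clearly above compound 2: the step of a 5.0-fold higher number from compound 2 to compound 3 (0.70 log units; beyond the scatter) is beyond the usual scatter, while the step of no change at the digits printed from compound 1 to compound 3 (within the scatter) is not.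

Compound 4 `O=C(/C(=C\c1c[nH]c2ccc(Br)cc12)SCc1ccc(F)cc1)c1ccc(Cl)cc1` differs from compound 3 in one place: 5-bromo-1H-indol-3-yl in place of 3-methylthiophen-2-yl on a double-bonded chain carbon bound to a double-bonded chain carbon.

For the measured compounds named here, only one measured step touches this position, the step from compound 2 to compound 3, where 3-methylthiophen-2-yl in place of 4-chlorophenyl raised the number by a modest but real amount. Compound 4 goes the other way, removing the 3-methylthiophen-2-yl group and putting a larger aromatic group there. The step from compound 1 to compound 3 concerns a different position and says nothing about this change. On that basis a lower number is expected for compound 4, of about the size seen between compound 2 and compound 3, so a 6.3-fold lower number from compound 3 to compound 4 (0.80 log units; beyond the scatter) is the estimated step. Compound 4 is therefore expected to give 8000 nM in this assay, within a range from 1500 nM to 40000 nM.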

Compound 4, concentration for 50% growth inhibition: 50000 nM
Compound 4: middle estimate off by 6.3-fold (0.80 log units), on the low side, outside the stated range (above it).
By their numbers in this assay, from the lowest: compound 2; then compounds 1, 3 and 4 (each within the scatter of the next).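

In this assay the change reads as no change at the digits printed from compound 3 to compound 4 (within the scatter) and so the number at this place on the double-bonded chain carbon stays put, even though the entering 5-bromo-1H-indol-3-yl is larger than 3-methylthiophen-2-yl and brings a six-membered aromatic ring of carbon only and a hydrogen-bond donor. Among compounds that differ only here, 4-chlorophenyl is the group that stands apart, since a 5.0-fold higher number from compound 2 to compound 4 (0.70 log units; beyond the scatter) is the same size as the earlier 5.0-fold higher number from compound 2 to compound 3 (0.70 log units; beyond the scatter) and two very different groups therefore land at the same level. Nothing available explains why these two groups read alike or why 4-chlorophenyl differs.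

From the compounds shown here alone, what remains open is whether the lower number belongs to 4-chlorophenyl alone or extends to close relatives at this place, such as plain phenyl or 4-methoxyphenyl. Going by these compounds, it is also open whether the bromine of the indole group matters here, which 1H-indol-3-yl without bromine would test, and whether a non-aromatic group such as cyclohexyl would fit the same picture.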